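Chloro in Place of Methoxy: Expecting Compound 4

The source may report more compounds than this note shows. Statements on the series, on what has been measured and on what is new or still open speak of the compounds shown alone.

Three compounds have been measured in a functional assay on HL-60 cells (Homo sapiens) for cytotoxicity, read by CCK-8 assay, with a stated time of 72 h; a higher number here means a weaker inhibitor, a lower number a stronger inhibitor:

Compound 1, `COc1ccc2c(c1)/C(=C\C(=O)OC(C)(C)C)C(=O)N2`, gives 6190 nM.
Compound 2, `COc1cccc2c1NC(=O)/C2=C/C(=O)OC(C)(C)C`, gives 9680 nM.
Compound 3, `CC(C)(C)OC(=O)/C=C1/C(=O)Nc2ccc(Cl)cc21`, gives 3160 nM.

Compound 1 and compound 2 are built from the same atoms joined differently; the difference between the two cores is not broken down here. In this assay compound 2 and compound 1 lie within the usual scatter of each other, while the gap from compound 2 to compound 3 lies beyond it.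

Compound 1 and compound 3 differ in one place: chloro in place of methoxy on an aromatic carbon. That change gave a 2.0-fold lower number from compound 1 to compound 3 (0.29 log units; within the scatter), a step that sits within the scatter.

Compound 4, `CC(C)(C)OC(=O)/C=C1/C(=O)Nc2c(Cl)cccc21`, has not yet been measured in this assay. It stands to compound 2 as compound 3 stands to compound 1: chloro in place of methoxy on an aromatic carbon. The surroundings are not identical, though. In compound 3 the chloro sits meta to a fused ring and para to a fused ring; in compound 4 it sits ortho to a fused ring and meta to a fused ring. The change is therefore the same kind of change, not the same change.

Within the data shown here, with only one earlier example, the expectation rests on compound 1 and compound 3, whose change produced a 2.0-fold lower number from compound 1 to compound 3 (0.29 log units; within the scatter); a step of similar size, a 1.9-fold lower number from compound 2 to compound 4 (0.29 log units; within the scatter), is expected here. Compound 4 is accordingly estimated at 5000 nM in this assay, with a plausible range from 2000 nM to 12000 nM.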

Compound 4, half-maximal inhibitory concentration: 6120 nM
Compound 4: middle estimate off by 1.2-fold (0.09 log units), on the low side; the range from low to high includes it.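

In this assay, chloro in place of methoxy on an aromatic carbon now has a second reading on a different core, a 1.6-fold lower number from compound 2 to compound 4 (0.20 log units; within the scatter), and this step, like the earlier one, lies within the usual scatter of the measurement. Set side by side, the two readings agree, so in this small series the change carried over from one core to the other without any detectable difference in its size: the same change on two cores in this assay, a 2.0-fold lower number (0.29 log units; within the scatter) from compound 1 to compound 3 and a 1.6-fold lower number (0.20 log units; within the scatter) from compound 2 to compound 4, 1.2-fold (0.09 log units) apart, within the scatter of two such steps

This does not show that chloro truly lowers the number on either core, since neither step can be told apart from the scatter on its own, and two pairs of compounds are too few to establish a rule for the series, even though the chloro of compound 4 sits ortho to a fused ring and meta to a fused ring and the step still matched.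

The compounds shown leave open how other groups on these aromatic carbons, such as a fluoro, a nitrile or an amine, would read in this assay. As far as these compounds go, all four also carry the same tert-butyl ester, so the effect of a carboxylic acid or a longer chain in its place remains unknown.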